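Taking the acetyl group off compound 1

The source may report more compounds than this note shows. Statements on the series, on what has been measured and on what is new or still open speak of the compounds shown alone.

Among the measured compounds shown here, in a functional assay on SGC-7901 cells (Homo sapiens) for antiproliferative activity, read by sulforhodamine B assay, with a stated time of 72 h (on this read-out lower numbers stand for stronger inhibition and higher numbers for weaker inhibition), compound 1 `CC(=O)Oc1cc2c(CC[C@@H]3OC(C)(C)OC3(C)C)c(C)ccc2cc1C(C)C` gives 88900 nM, the higher of the two numbers so far, while compound 2 `CC(=O)Oc1cc2c(CC[C@H]3OC(C)(C)OC3(C)C)c(C)ccc2cc1C(C)C` gives 36700 nM. The next molecule, compound 3 `Cc1ccc2cc(C(C)C)c(O)cc2c1CC[C@@H]1OC(C)(C)OC1(C)C`, keeps the configuration of compound 1 but changes one group: hydrogen in place of acetyl on an oxygen on an aromatic ring. In short, acetoxy becomes hydroxy. For the measured compounds named here, the only measured step is a 2.4-fold lower number from compound 1 to compound 2 (0.38 log units; beyond the scatter), and it goes with the fact that compounds 1 and 2 differ only in the configuration as drawn. That step never touches this oxygen, so it offers only a sense of how far numbers move in this small set, not a direct precedent. A modest move towards a lower number therefore seems a reasonable, though uncertain, expectation. The estimated step is a 2.2-fold lower number from compound 1 to compound 3 (0.35 log units; beyond the scatter). For compound 3 the expected value is 40000 nM, with an estimated range from 12000 nM to 100000 nM.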

Compound 3, half-maximal inhibitory concentration: 31700 nM
Estimate against measurement, compound 3: 1.3-fold (0.10 log units) above, within the range that was stated.
By their numbers in this assay, from the lowest: compounds 3 and 2 (each within the scatter of the next); then compound 1.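

In this assay this oxygen on the aromatic ring now has a step of its own: with hydrogen in place of acetyl, so that acetoxy becomes hydroxy, the result is a 2.8-fold lower number from compound 1 to compound 3 (0.45 log units; beyond the scatter). Among the compounds shown here, this is the first sign that the group on this oxygen can shift the number, as the earlier pair both carry acetyl and differ only in configuration. Nothing given here accounts for why this change goes with a lower number.

Only acetyl and hydrogen appear on this oxygen, leaving open how a methyl group, forming a methyl ether, or a longer acyl chain such as butyryl would fare. As far as these compounds go, whether the same change gives a similar step in the configuration of compound 2 also remains open.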